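The source may report more compounds than this note shows. Statements on the series, on what has been measured and on what is new or still open speak of the compounds shown alone.

Working notes on the series. In a functional assay on A2780 cells (Homo sapiens) for antiproliferative activity, read by sulforhodamine B assay, with a stated time of 48 h (on this read-out higher numbers stand for weaker inhibition of growth and lower numbers for stronger inhibition of growth), compound 1 (`COC(=O)/C=C\[C@H]1OCCC[C@H]1O[Si](C)(C)C(C)(C)C`), with its double bond drawn Z, gives 7300 nM. Compound 2 (`COC(=O)/C=C/[C@H]1OCCC[C@H]1O[Si](C)(C)C(C)(C)C`), with the double bond drawn E, gives 98000 nM, the higher of the two numbers and so the weaker growth inhibition. Among the measured compounds shown here, the only measured step is a 13-fold higher number from compound 1 to compound 2 (1.13 log units; beyond the scatter). It is a large step, and it can be assigned to the double bond because of the fact that compounds 1 and 2 differ only in the configuration as drawn.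

Compound 3 (`COC(=O)/C=C/[C@H]1OCCC[C@@H]1O[Si](C)(C)C(C)(C)C`) keeps the E double bond of compound 2 and changes elsewhere: the two compounds have the same atoms and bonds and differ only in configuration as drawn: 1 of 3 stereo elements differ; a stereocentre at a saturated ring carbon is drawn R in compound 2 and S in compound 3. For the measured compounds named here, no measured step alters a ring stereocentre, so that step bears on this change only indirectly: it shows that configuration alone can move a number substantially in this assay. The direction for the new change is not established by the data. Compound 2 stands at the weak end at 98000 nM, so a lower number is the more likely outcome, though a smaller move than the double-bond step. The estimated change is a 2.0-fold lower number from compound 2 to compound 3 (0.29 log units; within the scatter). For compound 3 the expected value is 50000 nM, with an estimated range of 14000 nM to 150000 nM.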

Compound 3, concentration for 50% growth inhibition: 28000 nM
Compound 3: the middle estimate sits 1.8-fold (0.25 log units) above what was measured; the measured number falls inside the stated range.
By their numbers in this assay, from the lowest: compound 1; then compound 3; then compound 2.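

In this assay the ring stereocentre now has a measured step of its own, a 3.5-fold lower number from compound 2 to compound 3 (0.54 log units; beyond the scatter), and with the double bond drawn E on both sides this step can be assigned to that centre: the fact that compounds 2 and 3 differ only in the configuration as drawn So, among the E compounds shown, the S centre gives the stronger growth inhibition, and configuration at a saturated ring carbon joins the double bond as a measured source of change, though this step is printed as modest and the double-bond step, a 13-fold higher number from compound 1 to compound 2 (1.13 log units; beyond the scatter), as large. The remaining step, a 3.8-fold higher number from compound 1 to compound 3 (0.58 log units; beyond the scatter), carries both configurational changes at once and cannot be divided between them, and compound 1 keeps the lowest number of the three: the fact that compounds 1 and 3 differ only in the configuration as drawn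

The compounds shown leave open how the ring stereocentre behaves with the double bond drawn Z, as they hold the S centre only with the E double bond, and what the second ring stereocentre contributes, as it is the same throughout. They also leave open what happens when a free hydroxyl replaces the silyl ether or a carboxylic acid replaces the methyl ester.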